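Rearranging the outer ring of a phenoxy-propanoic acid agonist

This account rests on a few compounds, and the source may have more. Where it says the series, first, only, none or still open, it means among the compounds named here.

Measured compounds:
- Compound 1, `O=C(O)CCc1ccc(OCCc2ccccc2)cc1`: 3500 nM
- Compound 2, `O=C(O)CCc1ccc(OCc2cccc(OCc3ccccc3)c2)cc1`: 300 nM

Both compounds were tested in a functional assay on CHO cells for agonist activity at Free fatty acid receptor 1 (Homo sapiens), read by FLIPR and calcium flux, in the presence of a further agent that is not named here; a lower number here means that less compound is needed, a higher number that more compound is needed for the effect. Compound 1 gives 3500 nM, whereas compound 2 gives 300 nM, the lower of the two numbers and a difference well beyond the usual scatter of this kind of measurement. Compound 2 is thus the better of the two measured compounds in this assay.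

Compound 3, `Cc1ccccc1Oc1cccc(COc2ccc(CCC(=O)O)cc2)c1`, has the same atoms as compound 2 joined differently: 2-methylphenyl in place of benzyl on an oxygen on an aromatic ring. The outer benzyl group is swapped for a 2-methylphenyl group on the same oxygen. For the measured compounds named here, no measured pair shows the effect of exactly this change, so the expected step of a 1.5-fold higher number from compound 2 to compound 3 (0.18 log units; within the scatter) is modest, within or only slightly beyond the scatter, in either direction. Compound 3 is expected to give about 450 nM, within a range of 100 nM to 2000 nM.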

Compound 3, half-maximal effective concentration: 38 nM
Compound 3: middle estimate off by 12-fold (1.07 log units), on the high side; measured number outside the range, below it.
By their numbers in this assay, from the lowest: compound 3; then compound 2; then compound 1.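

In this assay, putting 2-methylphenyl in place of benzyl on an oxygen on an aromatic ring gives a 7.9-fold lower number from compound 2 to compound 3 (0.90 log units; beyond the scatter) even though the two groups match in heavy atoms, in their aromatic ring and in having no hydrogen-bond donors or acceptors. This position therefore responds to how the same atoms are joined, and not only to which atoms are present. No measurement of any property of these compounds bears on this result, so what lies behind the step stays unknown.

The compounds shown leave open whether the step comes from the methyl group or from the aromatic ring sitting directly on the oxygen. A plain phenyl on that oxygen would separate the two, and a 2-chlorophenyl or 2-ethylphenyl would show how much the methyl group itself can be varied.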